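This account rests on a few compounds, and the source may have more. Where it says the series, first, only, none or still open, it means among the compounds named here.

Compound 1 `[O-]/[N+](=C\c1cn(-c2ccc(F)cc2)nn1)c1ccccc1` is the starting point of this step. Among the measured compounds shown here, in a functional assay on COLO 205 cells (Homo sapiens) for inhibition, read by MTT assay, with a stated time of 24 h (on this read-out lower numbers stand for stronger inhibition and higher numbers for weaker inhibition), compound 1 gives 10200 nM, the highest of the two numbers measured so far, although its only neighbour lies within the usual scatter. For the measured compounds named here, that neighbour is compound 2 `[O-]/[N+](=C\c1cn(-c2ccc(Cl)cc2)nn1)c1ccccc1`, which in this assay gives 9700 nM; the single measured step is a 1.1-fold lower number from compound 1 to compound 2 (0.02 log units; within the scatter), and it concerns a swap of one halogen for another on an aromatic carbon.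

Compound 3 `CC(C)(C)/[N+]([O-])=C/c1cn(-c2ccc(F)cc2)nn1` has not yet been measured. It differs from compound 1 in one place: tert-butyl in place of phenyl on a double-bonded nitrogen. Going by the values given here, this change sits at a different spot from the only measured step, so no measured step bears on it, and the measured pair gives no direction to expect. With nothing pointing up or down, the sensible expectation is a number close to that of compound 1, with a wide margin for uncertainty. Compound 3 is therefore expected to give about 10000 nM in this assay, with a range from 3000 nM to 35000 nM. The estimated step is a 1.0-fold lower number from compound 1 to compound 3 (0.01 log units; within the scatter).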

Compound 3, half-maximal inhibitory concentration: 58900 nM
Estimate against measurement, compound 3: 5.9-fold (0.77 log units) below; the measured number lies above the stated range.
By their numbers in this assay, from the lowest: compounds 2 and 1 (each within the scatter of the next); then compound 3.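

The earlier pair changed only a halogen and stayed within the scatter, so it said nothing about the group on the double-bonded nitrogen. In this assay, putting tert-butyl in place of phenyl at this nitrogen gives a 5.8-fold higher number from compound 1 to compound 3 (0.76 log units; beyond the scatter), a modest step but one beyond the scatter, so this position is not indifferent to the group it carries, and compound 1 stands for stronger inhibition than compound 3. Neither group has hydrogen-bond donors or acceptors or a net charge, and no available evidence explains the change in the number.

With only phenyl and tert-butyl shown at this position, it remains open whether the higher number belongs to tert-butyl alone or would also appear with other groups without an aromatic ring, such as methyl or cyclohexyl. From the compounds shown here alone, it is also open whether a phenyl ring carrying a methoxy group or an amine would lower the number, and whether the same step would appear with chloro in place of fluoro on the aromatic carbon.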